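The source may hold more compounds than are shown below. What is called first, only, known or untested is meant among the compounds shown, and "the series" means these compounds.

Working notes on the series. Compound 1 `CC1CC/C(=N\Nc2ccc(F)cc2)c2ncc(C(=O)O)c(=O)n21` carries a 4-fluorophenyl group on the amine nitrogen of the shared core, compound 2 `CC1CC/C(=N\Nc2cccc(Cl)c2)c2ncc(C(=O)O)c(=O)n21` a 3-chlorophenyl group in the same place. In a functional assay on the whole organism for inhibition, with Rattus norvegicus as the target (on this read-out higher numbers stand for an effect only at larger amounts of compound and lower numbers for an effect already at smaller amounts), compound 1 gives only a limit of the assay, > 1000 umol/kg. In this assay compound 2 also gives only a limit, > 100 umol/kg. The measured step that the two limits leave unreadable from compound 1 to compound 2 therefore cannot be read, and it gives no size to carry forward. Compound 3 `CC1CC/C(=N\Nc2ccccc2Br)c2ncc(C(=O)O)c(=O)n21` differs from compound 2 by 2-bromophenyl in place of 3-chlorophenyl on an amine nitrogen. For the measured compounds named here, no measured step gives a readable size for exchanging the aryl group on this nitrogen, so no direction beyond the scatter is expected for this change. The estimate for compound 3 in this assay is 300 umol/kg, with an expected range from 50 umol/kg to 3000 umol/kg. The step this estimate implies, a step that the limit leaves unreadable from compound 2 to compound 3, is an expectation only, and a further limit rather than a number is thought the likelier outcome.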

Compound 3, dose for 50% inhibition: > 320 umol/kg
Compound 3 was reported as a limit; the forecaster's own chance of this, stated with the estimate: 75%; middle value at least 1.0-fold (0.02 log units) away from the limit.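

Compound 1, compound 2 and compound 3 all give only limits in this assay, so none of the steps among them can be read. The compounds shown leave open what size of effect, if any, exchanging the aryl group on this amine nitrogen has.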